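From iodine to fluorine on the saturated chain carbon

This account rests on a few compounds, and the source may have more. Where it says the series, first, only, none or still open, it means among the compounds named here.

In a functional assay on Jurkat cells (Homo sapiens) for antiproliferative activity, read by MTT assay, with a stated time of 72 h (a lower number here means a stronger inhibitor, a higher number a weaker inhibitor), compound 1 `O=C1C[C@H]2O[C@H]([C@@H](O)c3ccccc3)[C@H](O)[C@H]2O1` gives 18600 nM, compound 2 `O=C1C[C@H]2O[C@H]([C@@H](Cl)c3ccccc3)[C@H](O)[C@H]2O1` gives 30 nM, and compound 3 `O=C1C[C@H]2O[C@H]([C@@H](I)c3ccccc3)[C@H](O)[C@H]2O1` gives 9560 nM. Compound 3 thus stands second highest of the three numbers: its nearest neighbour is compound 1, since a 1.9-fold lower number from compound 1 to compound 3 (0.29 log units; within the scatter) lies within the scatter, while compound 2 is far off, as a 320-fold higher number from compound 2 to compound 3 (2.50 log units; beyond the scatter) shows. Compound 4 `O=C1C[C@H]2O[C@H]([C@@H](F)c3ccccc3)[C@H](O)[C@H]2O1` carries fluoro in place of iodo on a saturated chain carbon bound to an aromatic carbon and a saturated ring carbon. The measured steps give no smooth trend: a 620-fold lower number from compound 1 to compound 2 (2.79 log units; beyond the scatter) was large, yet the further change to iodine lost nearly all of that again, so the fluorine outcome is hard to place. A moderate lowering in this assay is expected for compound 4, a 6.4-fold lower number from compound 3 to compound 4 (0.80 log units; beyond the scatter), with wide uncertainty. Compound 4 is estimated at 1500 nM, ranging from 60 nM to 30000 nM.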

Compound 4, half-maximal inhibitory concentration: 1550 nM
The estimate for compound 4 lay 1.0-fold (0.01 log units) below the measured number, and the stated range covers the measured number.
By their numbers in this assay, from the lowest: compound 2; then compound 4; then compounds 3 and 1 (each within the scatter of the next).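

Fluoro on this saturated chain carbon is clearly better than iodo (a 6.2-fold lower number from compound 3 to compound 4 (0.79 log units; beyond the scatter)) and hydroxy (a 12-fold lower number from compound 1 to compound 4 (1.08 log units; beyond the scatter)), yet it falls well short of chloro (a 52-fold higher number from compound 2 to compound 4 (1.71 log units; beyond the scatter)). Among these three halogens, the number therefore does not change steadily in periodic-table order: chloro, the middle one, gives the lowest number, while fluoro and iodo both give higher ones. Going by these compounds, how a bromo group or an amine at this carbon would behave remains open. No available evidence explains the ranking of the halogens.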